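The source may report more compounds than this note shows. Statements on the series, on what has been measured and on what is new or still open speak of the compounds shown alone.

Compound 1 `Cc1cc(C(=O)N2CCCCc3ccccc32)ccc1CNC(=O)Nc1c(F)cccc1F` gives 2.1 nM in a functional assay on HEK293 cells for agonist activity at Vasopressin V2 receptor (Homo sapiens), read by a luciferase reporter and cAMP accumulation (on this read-out higher numbers stand for an effect only at larger amounts of compound and lower numbers for an effect already at smaller amounts), the lowest of the three numbers recorded. Compound 2 `Cc1cc(C(=O)N2CCCCc3ccccc32)ccc1CNC(=O)NCC(=O)OC(C)C` gives 140 nM in this assay, and compound 3 `Cc1cc(C(=O)N2CCCCc3ccccc32)ccc1CNC(=O)NCC(N)=O` gives 210 nM there. Compound 4 `Cc1cc(C(=O)N2CCCCc3ccccc32)ccc1CNC(=O)N1C[C@H](O)C[C@H]1C(=O)N(C)C` has not yet been measured; its change from compound 1 is 2-(dimethylcarbamoyl)-4-hydroxypyrrolidin-1-yl in place of (2,6-difluorophenyl)amino on a carbonyl carbon. Among the measured compounds shown here, two measured steps bear on this change, each of them likewise taking the 2,6-difluorophenyl away from the amide-type nitrogen: a 67-fold higher number from compound 1 to compound 2 (1.82 log units; beyond the scatter) and a 100-fold higher number from compound 1 to compound 3 (2.00 log units; beyond the scatter), both large. The two replacements differ little from one another, a 1.5-fold higher number from compound 2 to compound 3 (0.18 log units; within the scatter). A large rise in this assay is therefore expected for compound 4, a 71-fold higher number from compound 1 to compound 4 (1.85 log units; beyond the scatter). The estimate for compound 4 is 150 nM, expected to lie between 30 nM and 800 nM.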

Compound 4, half-maximal effective concentration: 2.3 nM
Estimate against measurement, compound 4: 65-fold (1.81 log units) above; the measured number lies below the stated range.
By their numbers in this assay, from the lowest: compounds 1 and 4 (each within the scatter of the next); then compounds 2 and 3 (each within the scatter of the next).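

Compound 4 shows that an aromatic ring is not needed on this carbonyl carbon: with 2-(dimethylcarbamoyl)-4-hydroxypyrrolidin-1-yl in place of (2,6-difluorophenyl)amino, this assay gives a 1.1-fold higher number from compound 1 to compound 4 (0.04 log units; within the scatter). The large rises seen earlier therefore do not follow from the loss of that ring alone, as the replacement of the open-chain groups shows: a 91-fold lower number from compound 3 to compound 4 (1.96 log units; beyond the scatter) and a 61-fold lower number from compound 2 to compound 4 (1.78 log units; beyond the scatter). Nothing available explains this difference. The compounds shown leave open whether the hydroxy group, the dimethylcarbamoyl group or the two stereocentres carry this result, and whether an unsubstituted pyrrolidin-1-yl or piperidin-1-yl would read the same.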